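Bromo in place of nitro on the shared core of compound 1

The source may report more compounds than this note shows. Statements on the series, on what has been measured and on what is new or still open speak of the compounds shown alone.

Measured so far in a functional assay on A549 cells (Homo sapiens) for antiproliferative activity, read by MTT assay; on this read-out lower numbers stand for stronger inhibition and higher numbers for weaker inhibition:
- Compound 1, `O=C1N=C(N2CCC[C@H]2C(=O)Nc2ccc3ncnc(Nc4cccc(Cl)c4)c3c2)S/C1=C/c1ccccc1[N+](=O)[O-]`, gives > 50000 nM.
- Compound 2, `COc1ccccc1/C=C1/SC(N2CCC[C@H]2C(=O)Nc2ccc3ncnc(Nc4cccc(Cl)c4)c3c2)=NC1=O`, gives > 50000 nM.

The value of compound 1 in this assay is a limit of the assay and not a number. The value of compound 2 is likewise only a limit. Both measured compounds rest at the limit of > 50000 nM in this assay, at which 2 of the 2 values shown sit, so compound 1 stands nowhere readable on the numbers shown. Within the data shown here, the single measured step, a step that the two limits leave unreadable from compound 1 to compound 2, gives no size either.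

Compound 3, `O=C1N=C(N2CCC[C@H]2C(=O)Nc2ccc3ncnc(Nc4cccc(Cl)c4)c3c2)S/C1=C/c1ccccc1Br`, has not been measured. It differs from compound 1 by bromo in place of nitro on an aromatic carbon. Among the measured compounds shown here, the only comparable step, methoxy in place of nitro on an aromatic carbon, gave a step that the two limits leave unreadable from compound 1 to compound 2, so no direction or size can be drawn from it. With both neighbours at the limit and no readable step, the expectation for compound 3 is that it also sits at the limit. Compound 3 is expected at 70000 nM, in a range from 20000 nM to 250000 nM. The step this estimate means, a step that the limit leaves unreadable from compound 1 to compound 3, is expected to stay within the scatter, because compound 1 gives > 50000 nM.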

Compound 3, half-maximal inhibitory concentration: > 50000 nM
Compound 3 was reported as a limit; the forecaster's own chance of this, stated with the estimate: 80%; the middle value is on the limit's open side.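

In this assay compound 3 gives > 50000 nM, a limit of the assay and not a number. No new step can be read from compound 3 to compound 1 or compound 2, as all three compounds rest at one limit: the limit of > 50000 nM in this assay, at which 3 of the 3 values shown sit.

Left open is how far nitro, methoxy and bromo stand from one another in this assay, and whether any group at this place on the shared core gives a readable value.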